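A Second Chloro Group, Tested on a Different Core

The source may hold more compounds than are shown below. What is called first, only, known or untested is meant among the compounds shown, and "the series" means these compounds.

Measured in a functional assay on SW1573 cells (Homo sapiens) for inhibition, read by sulforhodamine B assay, with a stated time of 48 h; on this read-out lower numbers stand for stronger inhibition of growth and higher numbers for weaker inhibition of growth:

compound 1, `CC(=O)OC/C(=C\c1ccc(Cl)cc1)C(=O)c1ccc(Cl)cc1`: 3400 nM
compound 2, `CC(=O)OC/C(=C\c1ccc(Cl)cc1Cl)C(=O)c1ccc(Cl)cc1`: 3400 nM
compound 3, `CC(=O)OC/C(=C/c1ccccc1Cl)C(=O)c1ccccc1`: 14000 nM

Compound 1 and compound 2 share a core and differ in one place only: chloro in place of hydrogen on an aromatic carbon. In this assay the step of no change at the digits printed from compound 1 to compound 2 (within the scatter), so adding the second chloro group left the growth inhibition where it was.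

Compound 3 stands apart. Its value is the highest of the three, and the difference between its core and the core of compound 1 is not broken down here; the two structures simply differ in more than one place.

Compound 4, `CC(=O)OC/C(=C/c1ccc(Cl)cc1Cl)C(=O)c1ccccc1`, has not yet been measured. It differs from compound 3 by chloro in place of hydrogen on an aromatic carbon. For the measured compounds named here, this is the same kind of change as the one from compound 1 to compound 2, but the surroundings of the place are not identical: in compound 1 the carbon that takes the chloro group is ortho to a large group and meta to a chloro group, whereas in compound 3 it is meta to a chloro group and para to a large group.

Because the step of no change at the digits printed from compound 1 to compound 2 (within the scatter), the expectation is that the same kind of change on compound 3 will also leave the number roughly where it is, so the expected step is no change at the digits printed from compound 3 to compound 4 (within the scatter). Compound 4 is therefore estimated at 14000 nM in this assay, with a likely range from 6000 nM to 32000 nM.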

Compound 4, concentration for 50% growth inhibition: 22000 nM
Compound 4: the middle estimate sits 1.6-fold (0.20 log units) below what was measured; the measured number falls inside the stated range.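

Putting chloro in place of hydrogen on an aromatic carbon of compound 3 gives, in this assay, a 1.6-fold higher number from compound 3 to compound 4 (0.20 log units; within the scatter) and so, on this second core as well, leaves growth inhibition about where it stood. Set side by side, the two steps tell the same story, and the gap between them is no larger than repeat measurements would produce: the same change on two cores in this assay, no change at the digits printed (within the scatter) from compound 1 to compound 2 and a 1.6-fold higher number (0.20 log units; within the scatter) from compound 3 to compound 4, 1.6-fold (0.20 log units) apart, within the scatter of two such steps.
This shows that, between these two cores, the change carried over without any shift that can be told from the scatter, but it rests on just two pairs and a single kind of change, so it does not show that the same would hold on any other core or at any other place on the ring.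

The compounds shown carry only chloro as the added group, which leaves open whether a methoxy group, an amine or a carboxylic acid at this place, meta to a chloro group and para to a large group, would move the number. Also open, going by these compounds, is which of the differences between the core of compound 1 and the core of compound 3 matters for growth inhibition, as those two structures differ in more than one place.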